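This account rests on a few compounds, and the source may have more. Where it says the series, first, only, none or still open, it means among the compounds named here.

Measured so far:
compound 1, `Fc1ccc(C2CC(c3ccccc3)=NN2c2ccc(-c3ccccc3)nn2)cc1`, gives 100000 nM
compound 2, `Clc1ccc(C2=NN(c3ccc(-c4ccccc4)nn3)C(c3ccccc3)C2)cc1`, gives 10000 nM
compound 3, `Clc1ccc(C2=NN(c3ccc(-c4ccccc4)nn3)C(c3ccc(Cl)cc3)C2)cc1`, gives 8800 nM

These three compounds share one core and differ only in the groups on the two outer phenyl rings. In a functional assay on MCF7 cells (Homo sapiens) for antiproliferative activity, read by MTT assay, with a stated time of 24 h (on this read-out lower numbers stand for stronger inhibition and higher numbers for weaker inhibition), compound 3 has the lowest of the three numbers, but compound 2 lies within the usual scatter of it, so the two cannot be told apart; compound 1 stands clearly higher than both.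

Compound 4, `Fc1ccc(C2CC(c3ccc(Cl)cc3)=NN2c2ccc(-c3ccccc3)nn2)cc1`, follows from compound 3 by fluoro in place of chloro on an aromatic carbon. Within the data shown here, one measured step concerns the same ring: a 1.1-fold lower number from compound 2 to compound 3 (0.06 log units; within the scatter). Putting a chloro there instead of hydrogen therefore changed the number only within the scatter. Among the measured compounds shown here, compound 1 also carries fluoro on this ring, yet it lacks the chloro on the other ring, so no single step connects it to compound 3; its much higher value remains a caution, not a guide. For the measured compounds named here, with the only comparable step so small, the swap in compound 4 is expected to move the number by little, if anything, with a slight lean toward a higher value: a 1.4-fold higher number from compound 3 to compound 4 (0.13 log units; within the scatter). Compound 4 is thus estimated at 12000 nM, within a range from 5000 nM to 35000 nM.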

Compound 4, half-maximal inhibitory concentration: 3750 nM
Compound 4: the middle estimate sits 3.2-fold (0.51 log units) above what was measured; the measured number lies below the stated range.
By their numbers in this assay, from the lowest: compound 4; then compounds 3 and 2 (each within the scatter of the next); then compound 1.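

Compound 4 shows that this position can respond after all: in this assay, the 4-chlorophenyl to 4-fluorophenyl change gives a 2.3-fold lower number from compound 3 to compound 4 (0.37 log units; beyond the scatter), and fluoro in place of hydrogen on the same ring gives a 2.7-fold lower number from compound 2 to compound 4 (0.43 log units; beyond the scatter). Before this, the only step on this ring, chloro in place of hydrogen, had stayed within the scatter, so the ring now separates fluoro from both chloro and hydrogen, although each of these steps is only modest. Compound 4 also gives the first step on the other outer ring, a 27-fold lower number from compound 1 to compound 4 (1.43 log units; beyond the scatter), which shows that chloro in place of hydrogen has no fixed size in this series: the same change on two cores in this assay, a 1.1-fold lower number (0.06 log units; within the scatter) from compound 2 to compound 3 and a 27-fold lower number (1.43 log units; beyond the scatter) from compound 1 to compound 4, 23-fold (1.37 log units) apart, beyond the scatter of two such steps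

The compounds shown leave open whether a methoxy group, an amine or a carboxylic acid on the 4-fluorophenyl ring would give a lower or a higher number than fluoro. They also cannot tell why the two chloro steps differ so widely, since the two steps sit on different rings and on different partner groups.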